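Methyl on the aromatic oxygen: compound 1 to compound 3

The source may hold more compounds than are shown below. What is called first, only, known or untested is meant among the compounds shown, and "the series" means these compounds.

Measured so far:
compound 1, `O=C(Nc1cccc(O)c1)c1nccc2ccccc12`: in a functional assay on NUGC-3 cells (Homo sapiens) for inhibition, read by sulforhodamine B assay, with a stated time of 48 h (a higher number here means a weaker inhibitor of growth, a lower number a stronger inhibitor of growth), compound 1 gives only a limit, > 10000 nM.
compound 2, `COc1ccc(NC(=O)C2c3ccccc3CCN2C(=O)c2ccc(Cl)cc2)cc1`: in this assay compound 2 gives 3630 nM.

Compound 1 stands at the limit of this assay and carries no number of its own; the reading for compound 1 is the limit of > 10000 nM in this assay, at which 1 of the 2 values shown sits. Among the measured compounds shown here, compound 2 is built on a different core, so the two values show only that one compound sits at the limit while the other returns a number; no step between them is counted.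

Compound 3, `COc1cccc(NC(=O)c2nccc3ccccc23)c1`, keeps the core of compound 1 and differs in one place: methyl in place of hydrogen on an oxygen on an aromatic ring. Read one bond further out, the change is hydroxy to methoxy. For the measured compounds named here, no measured pair shows this change, so the step rests on expectation alone. With compound 1 at the limit of this assay, the step from compound 1 to compound 3 is expected to be small, a step that the limit leaves unreadable from compound 1 to compound 3, with no direction beyond the usual scatter. Compound 3 is accordingly expected to give 12000 nM in this assay, within 4000 nM to 40000 nM, and a fair chance remains that only a limit is reported again.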

Compound 3, concentration for 50% growth inhibition: > 10000 nM
Compound 3 gave a limit, no number; the forecaster's own chance of this, stated with the estimate: 60%; the middle value is on the limit's open side.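

Compound 1 and compound 3 both stand as limits in this assay, so no step can be read for the change from hydroxy to methoxy: the limit of > 10000 nM in this assay, at which 2 of the 3 values shown sit.

The compounds shown leave open whether methyl in place of hydrogen on this oxygen changes growth inhibition at all on the shared core; neither compound returns a number.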